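The source may report more compounds than this note shows. Statements on the series, on what has been measured and on what is new or still open speak of the compounds shown alone.

Three amides on a shared core have so far been measured in a functional assay on MDA-MB-231 cells (Homo sapiens) for cytotoxicity, read by MTT assay, with a stated time of 72 h; a lower number here means a stronger inhibitor, a higher number a weaker inhibitor. Compound 1 `Cc1ccc(F)cc1NC(=O)CN1CCN(c2nnc(Cc3ccccc3)c3ccccc23)CC1` gives 19200 nM; compound 2 `COc1ccc(NC(=O)CN2CCN(c3nnc(Cc4ccccc4)c4ccccc34)CC2)cc1OC` gives 32200 nM; compound 3 `O=C(CN1CCN(c2nnc(Cc3ccccc3)c3ccccc23)CC1)Nc1ccc(F)c(Cl)c1` gives 7360 nM. Compound 3 stands lowest of the three numbers: nearest to it is compound 1, seen through a 2.6-fold lower number from compound 1 to compound 3 (0.42 log units; beyond the scatter), and furthest is compound 2, seen through a 4.4-fold lower number from compound 2 to compound 3 (0.64 log units; beyond the scatter). The remaining pair, a 1.7-fold higher number from compound 1 to compound 2 (0.22 log units; within the scatter), sits within the scatter.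

Compound 4 `Cc1ccccc1NC(=O)CN1CCN(c2nnc(Cc3ccccc3)c3ccccc23)CC1` is not yet measured. Against compound 3 the change is 2-methylphenyl in place of 3-chloro-4-fluorophenyl on an amide-type nitrogen. The 2-methylphenyl that enters is the closest relative of the 5-fluoro-2-methylphenyl carried by compound 1, so the step of a 2.6-fold lower number from compound 1 to compound 3 (0.42 log units; beyond the scatter) bears most directly here, read in the reverse sense; the step of a 4.4-fold lower number from compound 2 to compound 3 (0.64 log units; beyond the scatter) also shows that moving away from 3-chloro-4-fluorophenyl has so far gone with a higher number. A modest rise in number is therefore expected for compound 4, of about a 2.7-fold higher number from compound 3 to compound 4 (0.43 log units; beyond the scatter). Compound 4 is estimated at 20000 nM, within a range of 9000 nM to 45000 nM.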

Compound 4, half-maximal inhibitory concentration: 17300 nM
Compound 4: the middle estimate sits 1.2-fold (0.06 log units) above what was measured, and the stated range covers the measured number.
By their numbers in this assay, from the lowest: compound 3; then compounds 4, 1 and 2 (each within the scatter of the next).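

In this assay, hydrogen in place of fluoro on the aromatic ring gives a 1.1-fold lower number from compound 1 to compound 4 (0.05 log units; within the scatter), so this fluoro has no readable weight on the 2-methylphenyl amide. The unfluorinated ring also stays apart from 3-chloro-4-fluorophenyl, with a 2.4-fold higher number from compound 3 to compound 4 (0.37 log units; beyond the scatter), and compound 3 is now beyond the scatter of all three other amides. With a 1.9-fold lower number from compound 2 to compound 4 (0.27 log units; within the scatter), 2-methylphenyl and 3,4-dimethoxyphenyl cannot be told apart here, so only 3-chloro-4-fluorophenyl separates from the rest on this amide nitrogen.

No measurement at hand gives a reason for these differences. Still open, as far as these compounds go, are the separate contributions of the chloro and the fluoro in compound 3, and how an amine or a carboxylic acid on this aromatic ring would read.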